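The source may hold more compounds than are shown below. What is called first, only, known or untested is meant among the compounds shown, and "the series" means these compounds.

Measured so far:
- Compound 1 `CCN(CC)Cc1cc2cc(c1O)Oc1ccc(cc1)CCc1ccc(CN(CC)CC)c(O)c1-c1ccc(cc1O)CC2`: 1050 nM
- Compound 2 `Oc1cc2ccc1-c1c(ccc(CN3CCCC3)c1O)CCc1ccc(cc1)Oc1cc(cc(CN3CCCC3)c1O)CC2`: 430 nM
- Compound 3 `O=[N+]([O-])c1cc2cc(c1O)Oc1ccc(cc1)CCc1cccc(O)c1-c1ccc(cc1O)CC2`: > 20000 nM

These results come from a functional assay on MCF7 cells (Homo sapiens) for antiproliferative activity, read by MTT assay, with a stated time of 48 h; a lower number here means a stronger inhibitor, a higher number a weaker inhibitor. Compound 3 stands at > 20000 nM, which is a limit of the assay and not a number.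

Compound 4 `Nc1cc2cc(c1O)Oc1ccc(cc1)CCc1cccc(O)c1-c1ccc(cc1O)CC2` is made from the structure of compound 3 with one change, amino in place of nitro on an aromatic carbon, ortho to a hydroxy group: amino in place of nitro on an aromatic carbon.

Within the data shown here, no measured pair shows this change on its own, so the expectation rests on indirect evidence. Compound 1 at 1050 nM and compound 2 at 430 nM show that the shared core can give a measurable value in this assay, although they differ from compound 3 in more than one place. A moderate move towards stronger inhibition is therefore expected, though a second result at the limit remains possible. The expected size of this move is an at least 2.0-fold lower number from compound 3 to compound 4 (0.30 log units; that floor lies within the scatter). The estimate for compound 4 is 10000 nM, with an expected range of 4000 nM to 20000 nM.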

Compound 4, half-maximal inhibitory concentration: > 20000 nM
Compound 4: no number, only a limit; the forecaster's own chance of this, stated with the estimate: 35%; middle value at least 2.0-fold (0.30 log units) from the limit.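

Among these compounds, compound 3 and compound 4 both sit at the limit of this assay, which is not a number, so no step between them can be read: the limit of > 20000 nM in this assay, at which 2 of the 4 values shown sit. The compounds shown leave open how far each lies past that limit, and so whether amino in place of nitro changes the activity at all.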